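This account rests on a few compounds, and the source may have more. Where it says the series, first, only, none or still open, it means among the compounds named here.

In an assay on cells for inhibition of histone deacetylase 8 (Homo sapiens), read by fluorescence, with a stated time of 30 min (a lower number here means a stronger inhibitor, a higher number a weaker inhibitor), the three measured compounds gave these numbers:

Compound 1, `O=C1NC(=O)/C(=C\c2ccc(OCC(=O)N3N=C(c4ccccc4)CC3c3ccccc3Cl)cc2)S1`: 29000 nM
Compound 2, `O=C1NC(=O)/C(=C\c2ccc(OCC(=O)N3N=C(c4ccccc4)CC3c3ccc(C(F)(F)F)cc3)cc2)S1`: 16000 nM
Compound 3, `O=C1NC(=O)/C(=C\c2ccc(OCC(=O)N3N=C(c4ccccc4)CC3c3ccc(F)cc3)cc2)S1`: 26000 nM

Compound 3 stands second highest of these three numbers. Its nearest neighbour is reached by a 1.1-fold lower number from compound 1 to compound 3 (0.05 log units; within the scatter), its furthest by a 1.6-fold higher number from compound 2 to compound 3 (0.21 log units; within the scatter), and both of these lie within the scatter.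

Compound 4, `Cc1ccc(C2CC(c3ccccc3)=NN2C(=O)COc2ccc(/C=C3/SC(=O)NC3=O)cc2)cc1`, differs from compound 3 by methyl in place of fluoro on an aromatic carbon. The measured steps that bear on this are the earlier swaps of the aryl group on the saturated ring carbon: a 1.8-fold lower number from compound 1 to compound 2 (0.26 log units; within the scatter), a 1.1-fold lower number from compound 1 to compound 3 (0.05 log units; within the scatter) and a 1.6-fold higher number from compound 2 to compound 3 (0.21 log units; within the scatter), none of them beyond the scatter. In this assay the expected outcome is therefore no step beyond the scatter, a 1.1-fold lower number from compound 3 to compound 4 (0.03 log units; within the scatter). Compound 4 is estimated at 24000 nM, with a range from 10000 nM to 55000 nM.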

Compound 4, half-maximal inhibitory concentration: 31000 nM
The estimate for compound 4 lay 1.3-fold (0.11 log units) below the measured number; low and high end bracket the measured number.
By their numbers in this assay, from the lowest: compounds 2, 3, 1 and 4 (each within the scatter of the next).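

Methyl is the first group at this place, para to a large group, that carries no halogen, and in this assay it gives a 1.2-fold higher number from compound 3 to compound 4 (0.08 log units; within the scatter) against fluoro and a 1.9-fold higher number from compound 2 to compound 4 (0.29 log units; within the scatter) against trifluoromethyl. Set against the 2-chlorophenyl compound, 4-methylphenyl gives a 1.1-fold higher number from compound 1 to compound 4 (0.03 log units; within the scatter) as well. All four aryl groups shown therefore lie within the scatter of one another, and nothing given here accounts for that.

On these data alone, whether an amine or a carboxylic acid on this aromatic carbon would give a step beyond the scatter remains open.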